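Methoxy for methyl, repeated on a rearranged core

A few compounds are considered here, and "the series" means these few. Any claim that something is new, unique, unknown or untested is made for them only; others in the source may bear on it.

Measured compounds:
compound 1 `Cc1ccc(OC(=O)N(Nc2ccccc2)S(=O)(=O)c2ccccc2)cc1`: 1020 nM
compound 2 `COc1ccc(OC(=O)N(Nc2ccccc2)S(=O)(=O)c2ccccc2)cc1`: 584 nM
compound 3 `Cc1ccc(S(=O)(=O)N(Nc2ccccc2)C(=O)Oc2ccccc2)cc1`: 5720 nM

In a functional assay on RAW264.7 cells (Mus musculus), read by immunoassay, with a stated time of 24 h (a higher number here means a weaker inhibitor, a lower number a stronger inhibitor), compound 1 gives 1020 nM and compound 2 gives 584 nM. The change between them is methoxy in place of methyl on an aromatic carbon and the step it made was a 1.7-fold lower number from compound 1 to compound 2 (0.24 log units; within the scatter). Compound 3 has the same atoms as compound 1 joined differently; the difference between the two cores is not broken down here. In this assay compound 3 gives 5720 nM, the highest number of the three, with compound 1 and compound 2 both giving lower numbers beyond the usual scatter.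

Compound 4 `COc1ccc(S(=O)(=O)N(Nc2ccccc2)C(=O)Oc2ccccc2)cc1` is not yet measured. It differs from compound 3 by methoxy in place of methyl on an aromatic carbon, the same change as that from compound 1 to compound 2. The expected step is a 1.7-fold lower number from compound 3 to compound 4 (0.23 log units; within the scatter), set beside a 1.7-fold lower number from compound 1 to compound 2 (0.24 log units; within the scatter), resting on that single measured step. Compound 4 is therefore expected to give about 3400 nM, between 1500 nM and 8000 nM.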

Compound 4, half-maximal inhibitory concentration: 4430 nM
Compound 4: middle estimate off by 1.3-fold (0.11 log units), on the low side, and the stated range covers the measured number.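

On the rearranged core, the same change gives a 1.3-fold lower number from compound 3 to compound 4 (0.11 log units; within the scatter) in this assay, again a small step. Set beside the earlier step, the two agree: the same change on two cores in this assay, a 1.7-fold lower number (0.24 log units; within the scatter) from compound 1 to compound 2 and a 1.3-fold lower number (0.11 log units; within the scatter) from compound 3 to compound 4, 1.4-fold (0.13 log units) apart, within the scatter of two such steps. Carrying methoxy in place of methyl from one core to the other therefore shows no measurable dependence on the core, but both steps lie within the usual scatter, so the data do not show that methoxy improves on methyl on either core, and two cores cannot speak for the wider series.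

The compounds shown carry only methyl or methoxy at this place, leaving open how an amine, a carboxylic acid or a longer chain would behave there. Also open, going by these compounds, is whether the difference between the two cores would persist with such groups.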